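The compounds below may be only part of what the source reports. "The series", "measured", "known", "first", "only" and "open" are said of these compounds alone.

Values in a functional assay on A-375 cells (Homo sapiens) for activation, with a stated time of 3 days; on this read-out higher numbers stand for an effect only at larger amounts of compound and lower numbers for an effect already at smaller amounts:
- compound 1 `O=C(Nc1ccc(-c2ccccc2)cc1)C1CCCN(Cc2ccc(F)c(F)c2)C1`: 5000 nM
- compound 2 `O=C(Nc1ccc(-c2ccncc2)cc1)C1CCCN(Cc2ccc(F)c(F)c2)C1`: 1180 nM
- compound 3 `O=C(Nc1ccc(-c2ccccn2)cc1)C1CCCN(Cc2ccc(F)c(F)c2)C1`: 11000 nM

Compound 3 carries the highest number of the three. Its nearest neighbour on the numbers shows a 2.2-fold higher number from compound 1 to compound 3 (0.34 log units; beyond the scatter), and the furthest shows a 9.3-fold higher number from compound 2 to compound 3 (0.97 log units; beyond the scatter).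

The step under consideration leads to compound 4 `O=C(Nc1ccc(-c2nccs2)cc1)C1CCCN(Cc2ccc(F)c(F)c2)C1`, not yet measured: 1,3-thiazol-2-yl in place of pyridin-2-yl on an aromatic carbon. The change sits on an aromatic carbon of a six-membered aromatic ring of carbon only, para to a large group.

Among the measured compounds shown here, all the measured steps changed the group at this same place. Beside the two above there is a 4.2-fold lower number from compound 1 to compound 2 (0.63 log units; beyond the scatter). The number therefore responds to this group, and it has moved both ways. For the measured compounds named here, none of the three measured compounds carries a five-membered aromatic ring, so no measured step gives the size of this change directly. In this assay, a step within the scatter is expected, leaning towards a lower number, with a modest step beyond the scatter still possible. The estimate means a 1.8-fold lower number from compound 3 to compound 4 (0.26 log units; within the scatter). Compound 4 is expected at 6000 nM, with an estimated range from 2000 nM to 18000 nM.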

Compound 4, half-maximal effective concentration: 800 nM
Compound 4: middle estimate off by 7.5-fold (0.88 log units), on the high side, outside the stated range (below it).
By their numbers in this assay, from the lowest: compounds 4 and 2 (each within the scatter of the next); then compound 1; then compound 3.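

In this assay, 1,3-thiazol-2-yl brings a five-membered aromatic ring to this place on the carbon-only six-membered aromatic ring, and replacing pyridin-2-yl with it gives a large step (a 14-fold lower number from compound 3 to compound 4 (1.14 log units; beyond the scatter)). The same group also separates clearly from phenyl (a 6.3-fold lower number from compound 1 to compound 4 (0.80 log units; beyond the scatter)) but not from pyridin-4-yl (a 1.5-fold lower number from compound 2 to compound 4 (0.17 log units; within the scatter)), so a low number at this place is shared by a six-membered and a five-membered ring, while compound 1 and compound 3 remain higher and show that a six-membered ring alone does not give it. No measurement at hand accounts for these differences.

On these data alone, whether the low number extends to other five-membered aromatic rings, such as oxazol-2-yl or thiophen-2-yl, or to a saturated ring such as morpholine at this place remains open. The compounds shown also leave open how an amine or a carboxylic acid carried on the 1,3-thiazol-2-yl ring would shift the number, since the rest of the shared core stays the same throughout.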